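A few compounds are considered here, and "the series" means these few. Any claim that something is new, unique, unknown or untested is made for them only; others in the source may bear on it.

Of the compounds shown here, two have been tested so far in a functional assay on PC-3 cells (Homo sapiens) for cytotoxicity; a lower number here means a stronger inhibitor, a higher number a weaker inhibitor. Compound 1, `Oc1ccccc1/C=N/n1cnnc1`, gives > 30000 nM, which is a limit of the assay and not a number. Compound 2, `Oc1ccc(/C=N/n2cnnc2)cc1`, gives > 30000 nM, again a limit rather than a number. The two compounds therefore stand at the same place: the limit of > 30000 nM in this assay, at which 2 of the 2 values shown sit. Compound 3, `COc1ccc(/C=N/n2cnnc2)cc1`, differs from compound 2 by methyl in place of hydrogen on an oxygen on an aromatic ring, with methyl in place of hydrogen on an oxygen on an aromatic ring, so that hydroxy becomes methoxy. Among the measured compounds shown here, no measured pair shows what this change does in this assay, and no step beyond the scatter is expected. The expected step that the limit leaves unreadable from compound 2 to compound 3 is accordingly small, and compound 3 may well be reported only as a limit once more. The estimated value for compound 3 is 32000 nM, with an expected range of 15000 nM to 60000 nM.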

Compound 3, half-maximal inhibitory concentration: > 30000 nM
Compound 3: only a limit was reported (the forecaster's own chance of this, stated with the estimate: 80%); the middle value does not contradict the limit.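

Compound 3 gives > 30000 nM in this assay, which is a limit of the assay and not a number. Among the compounds shown here, no step can therefore be read between compound 2 and compound 3. The compounds shown leave open how hydroxy and methoxy compare in this assay, as none of them has a value that is a number.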